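The source may report more compounds than this note shows. Statements on the series, on what has been measured and on what is new or still open speak of the compounds shown alone.

Working notes on the series, all read in a functional assay on HT-29 cells (Homo sapiens) for cytotoxicity, read by MTT assay, with a stated time of 72 h; a lower number here means a stronger inhibitor, a higher number a weaker inhibitor. Compound 1 `Nc1cccc(Nc2c(C(=O)NCc3ccc(F)cc3)nc(Br)c3cccnc23)c1` gives > 10000 nM, which is a limit and not a number. Compound 2 `O=C(NCCCNc1c(C(=O)NCc2ccc(F)cc2)nc(Br)c2cccnc12)c1ccccc1` gives > 10000 nM, also a limit. Compound 3 `CNCCCNc1c(C(=O)NCc2ccc(F)cc2)nc(Br)c2cccnc12` gives > 10000 nM, again a limit. All three therefore stand at the limit of > 10000 nM in this assay, at which 3 of the 3 values shown sit, and compound 3 has no readable rank among them.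

Compound 4 `COC(=O)CNc1c(C(=O)NCc2ccc(F)cc2)nc(Br)c2cccnc12` is still to be measured. Its difference from compound 3 is methoxycarbonyl in place of 2-(methylamino)ethyl on a saturated chain carbon bound to a nitrogen on an aromatic ring. Cut one bond further out, this reads 3-(methylamino)propyl to (methoxycarbonyl)methyl.

Going by the values given here, two measured steps bear on this change. The swap of 3-aminophenyl for 3-(methylamino)propyl on a nitrogen on an aromatic ring is a step that the two limits leave unreadable from compound 1 to compound 3. The swap of benzoyl for methyl on an amine nitrogen is a step that the two limits leave unreadable from compound 2 to compound 3. Neither has a size that can be carried over, so no direction can be expected, and a report of only a limit remains the likeliest outcome. The expected change is a step that the limit leaves unreadable from compound 3 to compound 4, with no real shift beyond the scatter anticipated. The estimate for compound 4 is 15000 nM, with an expected range from 6000 nM to 50000 nM.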

Compound 4, half-maximal inhibitory concentration: > 10000 nM
Compound 4: only a limit was reported (the forecaster's own chance of this, stated with the estimate: 70%); the middle value lies beyond the limit too.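

Compound 4 gives only a limit in this assay, as do compound 1, compound 2 and compound 3, so no step among these four compounds can be read: the limit of > 10000 nM in this assay, at which 4 of the 4 values shown sit.

The compounds shown leave open how the four compare with one another, and whether any group on a nitrogen on an aromatic ring changes the read-out.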